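The source may hold more compounds than are shown below. What is called first, only, known or untested is meant among the compounds shown, and "the series" means these compounds.

Among the compounds with values here, only two compounds have results so far in a functional assay on A498 cells (Homo sapiens) for cytotoxicity; a higher number here means a weaker inhibitor of growth, a lower number a stronger inhibitor of growth. Compound 1 `COc1ccc(C2=C(c3cc(OC)c(OC)c(OC)c3)CC3CCCN3C2=O)cc1O` is reported at > 100000 nM, which is a limit of the assay and not a number. Within the data shown here, compound 2 `COc1ccc(C2=C(c3ccc(SC)cc3)CC3CCCN3C2=O)cc1Br` gives 600 nM, the only true number available, so it serves as the single reference point for what follows.

Compound 3 `COc1ccc(C2=C(c3ccc(SC)cc3)CC3CCCN3C2=O)cc1C` is not yet measured. It keeps the structure of compound 2 except for one group: methyl in place of bromo on an aromatic carbon. In words, methyl takes the place of bromo on an aromatic carbon, ortho to a methoxy group, turning 3-bromo-4-methoxyphenyl into 4-methoxy-3-methylphenyl.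

Among the measured compounds shown here, no two measured compounds differ in just one place, so this kind of swap has no direct precedent here, and any forecast is uncertain. A small change toward weaker growth inhibition seems the most reasonable expectation, perhaps not much beyond the usual scatter. The expected size of this change is a 1.7-fold higher number from compound 2 to compound 3 (0.22 log units; within the scatter). Starting from compound 2 at 600 nM, the expected value for compound 3 is 1000 nM, with an estimated range from 250 nM to 5000 nM.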

Compound 3, concentration for 50% growth inhibition: 400 nM
Compound 3: middle estimate off by 2.5-fold (0.40 log units), on the high side, and the stated range covers the measured number.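

Within the data shown here, the exchange of bromo for methyl, on an aromatic carbon ortho to a methoxy group, is the first comparison here between two compounds that differ in one place, and in this assay it gives a 1.5-fold lower number from compound 2 to compound 3 (0.18 log units; within the scatter). For this one pair, the 3-bromo-4-methoxyphenyl and 4-methoxy-3-methylphenyl versions cannot be told apart, so growth inhibition in these cells does not depend on having bromine at this place, at least with the rest of the structure kept as it is here. The data shown give no reason why the two groups perform alike.

On these data alone, whether this position accepts other groups remains open, such as an amine, a carboxylic acid or a longer chain like propyl, and a single pair cannot show whether the same swap would behave alike on a different core. Compound 1 stays outside this comparison, as its > 100000 nM is a limit and not a number, and it differs from the other compounds in more than one place.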